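From Isopropyl to Methyl on a Carbonyl Carbon

The source may report more compounds than this note shows. Statements on the series, on what has been measured and on what is new or still open speak of the compounds shown alone.

Compound 1 `COc1cc(/C=C/C(=O)c2cccc(NC(=O)c3cc(Cl)cc(Cl)c3)c2)ccc1O` gives 0.75 ug/mL
Compound 2 `COc1cc(/C=C/C(=O)c2cccc(NC(=O)C(C)C)c2)ccc1O` gives 1.44 ug/mL

Both numbers come from a functional assay on HUVEC cells (Homo sapiens) for inhibition; on this read-out higher numbers stand for weaker inhibition and lower numbers for stronger inhibition. Repeated measurements of one compound also differ somewhat, so small gaps between compounds cannot be read as real differences. In this assay compound 2 gives 1.44 ug/mL and stands within the scatter of compound 1.

Compound 3 `COc1cc(/C=C/C(=O)c2cccc(NC(C)=O)c2)ccc1O` has not yet been measured. Its difference from compound 2 is methyl in place of isopropyl on a carbonyl carbon, which in words is methyl in place of isopropyl on a carbonyl carbon.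

Going by the values given here, only one measured step bears on this change, since it touches the same carbonyl carbon. There, isopropyl in place of 3,5-dichlorophenyl gave a 1.9-fold higher number from compound 1 to compound 2 (0.28 log units; within the scatter). A single step within the scatter offers no direction to carry forward. No step beyond the scatter is therefore expected in this assay. The expected result is a 1.0-fold higher number from compound 2 to compound 3 (0.02 log units; within the scatter), an estimate resting on that one step alone. Compound 3 is estimated at 1.5 ug/mL, with an expected range from 0.7 ug/mL to 3.2 ug/mL.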

Compound 3, half-maximal inhibitory concentration: 7.06 ug/mL
The estimate for compound 3 lay 4.7-fold (0.67 log units) below the measured number; the measured number lies above the stated range.
By their numbers in this assay, from the lowest: compounds 1 and 2 (each within the scatter of the next); then compound 3.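

The group on this carbonyl carbon turns out to matter: in this assay, methyl in place of isopropyl gives a 4.9-fold higher number from compound 2 to compound 3 (0.69 log units; beyond the scatter), although the earlier swap at the same carbon stayed within the scatter. Methyl in place of 3,5-dichlorophenyl gives a 9.4-fold higher number from compound 1 to compound 3 (0.97 log units; beyond the scatter), which makes compound 3, the acetamido member, the weakest inhibitor of the three, while compound 1 and compound 2 cannot be told apart despite carrying very different groups, a ring and a branched chain. So the read-out here does not follow every change at this position evenly, and the one clear loss among these three compounds comes with the single-carbon methyl group, although nothing available explains that loss.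

The compounds shown leave open where between methyl and isopropyl the loss sets in, and an ethyl group on the same carbonyl carbon would help to place it, as a plain phenyl ring would show whether the two chlorines of 3,5-dichlorophenyl count for anything. On these data alone, how a longer chain, or a chain ending in an amine or a carboxylic acid, would behave at this carbon also remains open.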